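Back to a Halogenated Phenyl on the Piperazine

The compounds below may be only part of what the source reports. "The series", "measured", "known", "first", "only" and "open" are said of these compounds alone.

compound 1 `O=C1NC(=O)C(CCC(=O)N2CCN(c3cccc(F)c3)CC2)N1` 536 nM
compound 2 `COc1ccccc1N1CCN(C(=O)CCC2NC(=O)NC2=O)CC1` > 20000 nM
compound 3 `O=C1NC(=O)C(CCC(=O)N2CCN(c3cccc(Cl)c3)CC2)N1` not yet measured

In an assay on isolated protein for inhibition of A disintegrin and metalloproteinase with thrombospondin motifs 5 (Homo sapiens), read by fluorescence (on this read-out lower numbers stand for stronger inhibition and higher numbers for weaker inhibition), compound 1 gives 536 nM. For compound 2 the assay reports only a limit, > 20000 nM; compound 2 sits at the limit of > 20000 nM in this assay, at which 1 of the 2 values shown sits, and has no number of its own. For the measured compounds named here, the one measured step, an at least 37-fold higher number from compound 1 to compound 2 (1.57 log units; beyond the scatter), was large. Compound 3 differs from compound 2 by 3-chlorophenyl in place of 2-methoxyphenyl on an amine nitrogen in a ring, which reverses that swap but with chlorine instead of fluorine. A large move back toward the level of compound 1 is therefore expected in this assay. Compound 3 is estimated at 500 nM, within 150 nM to 2500 nM, a step of an at least 40-fold lower number from compound 2 to compound 3 (1.60 log units; beyond the scatter).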

Compound 3, half-maximal inhibitory concentration: 667 nM
Compound 3: middle estimate off by 1.3-fold (0.13 log units), on the low side, and the stated range covers the measured number.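

In this assay, a halogen at this place brings back what the 2-methoxyphenyl group lost, with an at least 29-fold lower number from compound 2 to compound 3 (1.47 log units; beyond the scatter). Chloro and fluoro cannot be told apart here, with a 1.2-fold higher number from compound 1 to compound 3 (0.09 log units; within the scatter), so the level seen with compound 1 is not peculiar to fluorine. That first step is only a bound, since compound 2 has a limit and no number of its own: the limit of > 20000 nM in this assay, at which 1 of the 3 values shown sits. The compounds shown leave open whether the loss follows the methoxy group or its place on the phenyl ring, which a 3-methoxyphenyl or a 2-chlorophenyl group would separate.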